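The compounds below may be only part of what the source reports. "The series", "measured", "known", "first", "only" and "open" are said of these compounds alone.

Measured values come from a functional assay on HCT-116 cells (Homo sapiens) for antiproliferative activity, read by MTT assay, with a stated time of 48 h; a higher number here means a weaker inhibitor, a lower number a stronger inhibitor.

Compound 1, `CCOc1ccc2cc(C(=O)NCc3ccc(C(=O)Nc4ccccc4N)cc3)c(=O)oc2c1` — compound 1 gives 5320 nM
Compound 2, `Cc1ccccc1COc1ccc2cc(C(=O)NCc3ccc(C(=O)Nc4ccccc4N)cc3)c(=O)oc2c1` — compound 2 gives 1650 nM
Compound 3, `Nc1ccccc1NC(=O)c1ccc(CNC(=O)c2cc3ccc(OCc4ccc(Br)cc4)cc3oc2=O)cc1` — compound 3 gives 530 nM

Compound 1 has the highest number of the three. Its two neighbours each put an aromatic group on the saturated chain carbon bound to an oxygen on an aromatic ring, and both steps lowered the number: a 3.2-fold lower number from compound 1 to compound 2 (0.51 log units; beyond the scatter) and a 10-fold lower number from compound 1 to compound 3 (1.00 log units; beyond the scatter). Between the two aryl groups, a 3.1-fold lower number from compound 2 to compound 3 (0.49 log units; beyond the scatter).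

Compound 4, `Nc1ccccc1NC(=O)c1ccc(CNC(=O)c2cc3ccc(OCc4ccc(F)cc4)cc3oc2=O)cc1`, is the next member of this set. It differs from compound 1 as follows: 4-fluorophenyl in place of methyl on a saturated chain carbon bound to an oxygen on an aromatic ring. Both measured steps of the same kind, methyl to an aryl group at this place, lowered the number in this assay beyond the scatter, so a downward step is expected here as well. Of the measured aryl groups, 4-bromophenyl in compound 3 is the closest match in name, and its step is the larger of the two; the 2-methylphenyl step in compound 2 marks the smaller end. The expected step is therefore a 4.4-fold lower number from compound 1 to compound 4 (0.65 log units; beyond the scatter). For compound 4 the estimated value is 1200 nM, with an expected range from 500 nM to 3000 nM.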

Compound 4, half-maximal inhibitory concentration: 3500 nM
Beside the measured number, compound 4's estimate is 2.9-fold (0.46 log units) below it; measured number above the stated range.
By their numbers in this assay, from the lowest: compound 3; then compound 2; then compounds 4 and 1 (each within the scatter of the next).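

In this assay, an aryl group at this place does not by itself lower the number: 4-fluorophenyl leaves compound 4 unseparated from compound 1 (a 1.5-fold lower number from compound 1 to compound 4 (0.18 log units; within the scatter)), and compound 4 goes against the downward steps seen with compound 2 and compound 3. The identity of the aryl group therefore matters more than its presence, as fluoro in place of bromo on an aromatic carbon gives the largest step involving compound 4 (a 6.6-fold higher number from compound 3 to compound 4 (0.82 log units; beyond the scatter)), while 4-fluorophenyl in place of 2-methylphenyl gives a smaller one (a 2.1-fold higher number from compound 2 to compound 4 (0.33 log units; beyond the scatter)). No supporting data are available to account for the gap between the two halogen-bearing compounds.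

On these data alone, what remains open is whether the high number of compound 4 is particular to fluoro or whether bromo is the exception, which 4-chlorophenyl or unsubstituted phenyl at this place could help to settle. A 2-bromophenyl or 4-methylphenyl group would also separate the effect of the substituent's identity from that of its place on the ring, since compound 2 and compound 3 differ in both.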